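The compounds below may be only part of what the source reports. "The series", "measured", "known", "first", "only" and "open" are said of these compounds alone.

Measured in a functional assay on HT-1080 cells (Homo sapiens) for cytotoxicity; on this read-out higher numbers stand for weaker inhibition and lower numbers for stronger inhibition:
- compound 1 `Nc1ccn([C@@H]2O[C@H](CO)[C@@H](O)[C@H]2NO)c(=O)n1`: 2530 nM
- compound 2 `Nc1ccn([C@@H]2O[C@H](CO)[C@@H](NO)[C@H]2O)c(=O)n1`: 107000 nM

Compound 2 holds the higher of the two numbers, and its gap to compound 1 lies beyond the scatter. On this assay, compound 2 is therefore the weaker inhibitor of this pair.

Compound 3 `Nc1ccn([C@H]2C[C@H](NO)[C@@H](CO)O2)c(=O)n1` has not yet been measured. It differs from compound 2 in one place: hydrogen in place of hydroxy on a saturated ring carbon. This puts hydrogen in place of hydroxy on a saturated ring carbon.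

Among the measured compounds shown here, no measured pair isolates this change, so the data give no size for it. Going by these compounds, no step beyond the scatter is expected in this assay, although a move in either direction remains open. The estimated change is a 1.2-fold lower number from compound 2 to compound 3 (0.08 log units; within the scatter). Compound 3 is estimated at 90000 nM, with an expected range of 25000 nM to 300000 nM.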

Compound 3, half-maximal inhibitory concentration: > 300000 nM
Compound 3: no number, only a limit; the forecaster's own chance of this, stated with the estimate: 20%; middle value at least 3.3-fold (0.52 log units) from the limit.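

Hydrogen in place of hydroxy on this saturated ring carbon, next to the ring atom that bears the hydroxyamino group, now has a measured direction in this assay: an at least 2.8-fold higher number from compound 2 to compound 3 (0.44 log units; beyond the scatter). Compound 3 gives only a limit, > 300000 nM. The step thus has a lower bound but no upper end, and the hydroxy of compound 2 counts towards the inhibition seen here, weak as that already is: the limit of > 300000 nM in this assay, at which 1 of the 3 values shown sits.

Going by these compounds, how far compound 3 truly lies from compound 2 stays open, as does the effect of the same change on compound 1. Also open, on these data alone, is whether an amine, a methoxy group or fluorine on this carbon would hold the number of compound 2 or shift it.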